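Cytotoxicity in HEL Cells: Swapping tert-Butyl for Chloro

This account rests on a few compounds, and the source may have more. Where it says the series, first, only, none or still open, it means among the compounds named here.

Measured so far:
- Compound 1 `Cc1cn(CCCCCOc2ccc(Br)cc2)c(=O)[nH]c1=O`: 100000 nM
- Compound 2 `CC(C)(C)c1ccc(OCCCCCn2ccc(=O)[nH]c2=O)cc1`: 100000 nM
- Compound 3 `O=c1ccn(CCCCOc2ccc(Br)cc2)c(=O)[nH]1`: 100000 nM

Of the compounds shown here, three have been tested in an ADME assay on HEL cells (Homo sapiens) for cytotoxicity, read by microscopy (a higher number here means that more compound is tolerated, a lower number that less compound is tolerated), and each one reached the same reading. Compound 1 gives 100000 nM in this assay. Compound 2 gives 100000 nM in this assay. Compound 3 gives 100000 nM in this assay. Compound 2 therefore stands level with compounds 1 and 3 at the digits shown; its nearest neighbour by value is compound 1 and its furthest is compound 3, yet neither pair differs at the digits shown, so all three sit within the usual scatter of one another.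

Compound 4 `O=c1ccn(CCCCCOc2ccc(Cl)cc2)c(=O)[nH]1` has not yet been measured in this assay. It is related to compound 2 by a single change on the aromatic ring: chloro in place of tert-butyl on an aromatic carbon. The three compounds already measured carry different substituents on that ring and on the shared core, and none of them moved the reading, so there is no basis in these numbers for expecting compound 4 to move either. The expected step in this assay is none beyond the scatter. Compound 4 is estimated to give 100000 nM in this assay, with a range from 50000 nM to 200000 nM, which means an expected step of no change at the digits printed from compound 2 to compound 4 (within the scatter).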

Compound 4, minimum cytotoxic concentration: > 100000 nM
Compound 4 ended at the assay's limit; the forecaster's own chance of this, stated with the estimate: 30%; the middle value lies on the limit itself.
By their numbers in this assay, from the lowest: compounds 1, 2 and 3 (each within the scatter of the next).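

In this assay compound 4 gives > 100000 nM, which is a limit of the assay and not a number. Going by these compounds alone, this is the first comparison here between two compounds that differ in only one place, and it shows that swapping tert-butyl, with 4 heavy atoms, for chloro, with a single heavy atom, gives a number no lower from compound 2 to compound 4 (the limit leaves the size open) on this aromatic carbon, para to a large group. The size of this step cannot be read, because compound 4 sits at a limit: the limit of > 100000 nM in this assay, at which 1 of the 4 values shown sits.

All four compounds read at the top of the range, so these results do not show which change, if any, would make the compound less well tolerated. On these data alone, it remains open whether an amine or a carboxylic acid on this aromatic carbon, or a longer chain joining the aromatic ring to the shared core, would give a lower reading.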